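The compounds below may be only part of what the source reports. "The series", "measured", "known", "first", "only" and "open" are said of these compounds alone.

Compounds measured in a functional assay on MCF7 cells (Homo sapiens) for antiproliferative activity, read by sulforhodamine B assay, with a stated time of 48 h; on this read-out higher numbers stand for weaker inhibition of growth and lower numbers for stronger inhibition of growth:
Compound 1, `COc1ccc(Cn2cc(CNC(=O)c3cn(-c4ccccc4)nc3-c3ccccc3)nn2)cc1OC`, 12600 nM
Compound 2, `O=C(NCc1cn(Cc2ccc(Cl)cc2)nn1)c1cn(-c2ccccc2)nc1-c1ccc(F)cc1`, 130 nM
Compound 3, `COc1ccc(Cn2cc(CNC(=O)c3cn(-c4ccccc4)nc3-c3ccc(F)cc3)nn2)cc1`, 650 nM

Among these three numbers compound 3 stands second highest: its nearest neighbour is compound 2, and compound 1 lies furthest from it. Among the compounds with values here, the one step measured in one place, a 5.0-fold higher number from compound 2 to compound 3 (0.70 log units; beyond the scatter), changes a different part of the molecule and so bears only indirectly on what follows.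

Compound 4, `COc1ccc(Cn2cc(CNC(=O)c3cn(-c4ccccc4)nc3-c3ccc(F)cc3)nn2)cc1OC`, differs from compound 3 by methoxy in place of hydrogen on an aromatic carbon. Within the data shown here, no single measured step covers this change. What can be read is that compound 1 carries the same 3,4-dimethoxybenzyl group as compound 4 but lacks the fluorine on the other phenyl ring, and in this assay compound 1 gives 12600 nM, whereas compound 3 gives 650 nM. Compound 4 sits between these two in structure, so its number is expected to move toward that of compound 1, a step of a 5.4-fold higher number from compound 3 to compound 4 (0.73 log units; beyond the scatter) in this assay. Compound 4 is therefore estimated at 3500 nM, with a range from 1200 nM to 10000 nM.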

Compound 4, concentration for 50% growth inhibition: > 100000 nM
Compound 4: no number, only a limit; the forecaster's own chance of this, stated with the estimate: 5%; middle value at least 28-fold (1.45 log units) from the limit.
By their numbers in this assay, from the lowest: compound 2; then compound 3; then compound 1. At a limit, above all of these: compound 4.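

In this assay compound 4 gives no number, only a limit: the limit of > 100000 nM in this assay, at which 1 of the 4 values shown sits.

A single methoxy placed ortho to a methoxy group weighs far more than the earlier exchange of chloro for methoxy, with an at least 150-fold higher number from compound 3 to compound 4 (2.18 log units; beyond the scatter), and the full exchange of 4-chlorophenyl for 3,4-dimethoxyphenyl gives an at least 760-fold higher number from compound 2 to compound 4 (2.88 log units; beyond the scatter). With the 3,4-dimethoxybenzyl group in place, fluoro in place of hydrogen also goes with weaker inhibition of growth, with an at least 7.9-fold higher number from compound 1 to compound 4 (0.89 log units; beyond the scatter).

From the compounds shown here alone, whether a hydroxy, a fluoro or a methyl at this place would behave like the methoxy remains open. Also open, going by these compounds, is whether the 4-methoxybenzyl group, paired with hydrogen in place of the fluoro, would show the same direction for that exchange.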